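A few compounds are considered here, and "the series" means these few. Any claim that something is new, unique, unknown or untested is made for them only; others in the source may bear on it.

Of the compounds shown here, three built on a shared core have been measured in a functional assay on A549 cells (Homo sapiens) for antiproliferative activity, read by MTT assay, with a stated time of 48 h; a lower number here means a stronger inhibitor, a higher number a weaker inhibitor. Compound 2 `CCN(CC)CCn1c(N)c(-c2nc3ccccc3n2C)c2nc(C#N)c(C#N)nc21` gives > 50000 nM, which is a limit of the assay and not a number. Compound 3 `CN(C)CCCn1c(N)c(-c2nc3ccccc3n2C)c2nc(C#N)c(C#N)nc21` gives 11700 nM, the higher of the two actual numbers. Compound 1 `CN(C)CCCCn1c(N)c(-c2nc3ccccc3o2)c2nc(C#N)c(C#N)nc21` gives 5470 nM, a lower number by a margin just beyond the scatter.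

The next candidate is compound 4 `CN(C)CCCCn1c(N)c(-c2nc3ccccc3n2C)c2nc(C#N)c(C#N)nc21`. It differs from compound 3 as follows: (dimethylamino)methyl in place of dimethylamino on a saturated chain carbon, three bonds along the chain from an aromatic nitrogen. In effect, the 3-(dimethylamino)propyl chain becomes a 4-(dimethylamino)butyl chain.

Among the measured compounds shown here, only one measured step bears directly on this change. It is an at least 4.2-fold lower number from compound 2 to compound 3 (0.63 log units; beyond the scatter), where (dimethylamino)methyl replaces diethylamino two bonds along the chain from an aromatic nitrogen. That step also changes the amine substituents and starts from a limit, so it shows direction more than size. Compound 1, at 5470 nM, already carries the 4-(dimethylamino)butyl chain, but it differs from compound 4 elsewhere as well and is only a loose guide.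

A small move towards a lower number in this assay therefore seems likely, perhaps no larger than the scatter. The expected change is a 1.6-fold lower number from compound 3 to compound 4 (0.19 log units; within the scatter). Compound 4 is estimated at 7500 nM, with an expected range of 3000 nM to 20000 nM.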

Compound 4, half-maximal inhibitory concentration: 6150 nM
Beside the measured number, compound 4's estimate is 1.2-fold (0.09 log units) above it; the range from low to high includes it.
By their numbers in this assay, from the lowest: compounds 1, 4 and 3 (each within the scatter of the next, the first and the last beyond it). At a limit, above all of these: compound 2.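

In this assay, going from the 3-(dimethylamino)propyl chain to the 4-(dimethylamino)butyl chain gives a 1.9-fold lower number from compound 3 to compound 4 (0.28 log units; within the scatter), so these two chains cannot be told apart in this read-out. Among the compounds shown here, compound 4 also isolates the group on the aromatic carbon, which no earlier pair did: 1-methyl-1H-benzimidazol-2-yl in place of 1,3-benzoxazol-2-yl gives a 1.1-fold higher number from compound 1 to compound 4 (0.05 log units; within the scatter), and with the 4-(dimethylamino)butyl chain in place these two groups cannot be told apart in this assay either. The comparison with the diethylamino compound gives an at least 8.1-fold lower number from compound 2 to compound 4 (0.91 log units; beyond the scatter), but compound 2 stands at a limit, so this step gives a bound and not a size: the limit of > 50000 nM in this assay, at which 1 of the 4 values shown sits.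

Since that step changes both the chain length and the amine substituents, the compounds shown do not separate the share of each, and a 4-(diethylamino)butyl chain would be needed to do so. As far as these compounds go, it also remains open whether a longer chain, such as 5-(dimethylamino)pentyl, or a ring amine such as piperidine or morpholine at the chain end, would move the number in this assay beyond the scatter.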